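The compounds below may be only part of what the source reports. "The series", "measured", "known", "first", "only" and "open" are said of these compounds alone.

Measured so far: compound 1 `CNS(=O)(=O)c1ccc2c(c1)C(n1ccccc1=O)=CC(C)(C)O2` with 17.8 nM, compound 2 `CN(C)S(=O)(=O)c1ccc2c(c1)C(n1ccccc1=O)=CC(C)(C)O2` with 16.2 nM, and compound 3 `CN(c1ccccc1)S(=O)(=O)c1ccc2c(c1)C(n1ccccc1=O)=CC(C)(C)O2` with 1.74 nM, all in a functional assay with Rattus norvegicus as the target; on this read-out lower numbers stand for an effect already at smaller amounts and higher numbers for an effect only at larger amounts of compound.

Compound 1 gives the highest of the three numbers, with compound 2 within the scatter of it and compound 3 the furthest away. Compound 4 `CC1(C)C=C(n2ccccc2=O)c2cc(S(=O)(=O)c3ccccc3)ccc2O1` differs from compound 1 in one place: phenyl in place of methylamino on a sulfonyl sulfur. The closest measured step is a 10-fold lower number from compound 1 to compound 3 (1.01 log units; beyond the scatter), where phenyl also entered the sulfonamide group, while a 1.1-fold lower number from compound 1 to compound 2 (0.04 log units; within the scatter) shows that a methyl there changed nothing beyond the scatter. Because phenyl in compound 3 gave 1.74 nM, a lower number is expected for compound 4 too, though the phenyl now sits directly on the sulfonyl sulfur and the nitrogen is gone. The expected step is a 3.6-fold lower number from compound 1 to compound 4 (0.55 log units; beyond the scatter). Compound 4 is estimated at 5 nM, between 1.5 nM and 18 nM.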

Compound 4, half-maximal effective concentration: 17.4 nM
Beside the measured number, compound 4's estimate is 3.5-fold (0.54 log units) below it; measured number inside the range.
By their numbers in this assay, from the lowest: compound 3; then compounds 2, 4 and 1 (each within the scatter of the next).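

Phenyl placed directly on the sulfonyl sulfur does not repeat the gain of compound 3 (a 10-fold higher number from compound 3 to compound 4 (1.00 log units; beyond the scatter)), and it stays level with the smaller groups (a 1.0-fold lower number from compound 1 to compound 4 (0.01 log units; within the scatter); a 1.1-fold higher number from compound 2 to compound 4 (0.03 log units; within the scatter)). The low number of compound 3 therefore goes with the whole methyl(phenyl)amino group, not with a phenyl on the sulfonyl sulfur alone. No measurement shown here explains this difference.

Open, as far as these compounds go, is whether the low number needs a phenyl on the sulfonamide nitrogen specifically, or whether a benzyl group, a cyclohexyl ring or a pyridine ring there would serve as well.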